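A Methoxy in Place of a Nitro on the Benzyl Arm

A few compounds are considered here, and "the series" means these few. Any claim that something is new, unique, unknown or untested is made for them only; others in the source may bear on it.

Measured compounds in a functional assay on PC-9 cells (Homo sapiens) for inhibition, read by MTT assay, with a stated time of 72 h; a lower number here means a stronger inhibitor, a higher number a weaker inhibitor:
compound 1, `Cc1cc(Nc2cc(-c3ccccc3)[nH]n2)n2nc(SCc3ccc([N+](=O)[O-])cc3)nc2n1`, gives 7980 nM
compound 2, `Cc1cc(Nc2cc(-c3ccccc3)[nH]n2)n2nc(SCc3c(Cl)cccc3Cl)nc2n1`, gives 5180 nM

Both measured compounds share one core and differ only in the aromatic ring attached to the saturated chain carbon bound to a sulfur. Going by the values given here, compound 1 carries the 4-nitrophenyl there and stands at the highest of the two numbers; the only step from it, a 1.5-fold lower number from compound 1 to compound 2 (0.19 log units; within the scatter), is within the scatter, so the two compounds cannot be ranked against each other.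

Compound 3, `COc1ccc(CSc2nc3nc(C)cc(Nc4cc(-c5ccccc5)[nH]n4)n3n2)cc1`, keeps the same core and the same benzyl-sulfanyl arm but changes the group on that ring: methoxy in place of nitro on an aromatic carbon. Among the compounds with values here, no measured pair shows this exact exchange. Within the data shown here, the one step that touches the same ring, from compound 1 to compound 2, replaced the whole 4-nitrophenyl and still moved the number only within the scatter, which suggests this ring tolerates variation without a large shift in the assay. A change confined to the para group is therefore expected to be small as well, with no direction beyond the scatter, as a 1.2-fold lower number from compound 1 to compound 3 (0.09 log units; within the scatter). Compound 3 is estimated at 6500 nM, within a range of 2500 nM to 16000 nM.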

Compound 3, half-maximal inhibitory concentration: 8110 nM
Compound 3: middle estimate off by 1.2-fold (0.10 log units), on the low side; measured number inside the range.
By their numbers in this assay, from the lowest: compounds 2, 1 and 3 (each within the scatter of the next).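

In this assay, the exchange confined to the group on the ring, methoxy in place of nitro on an aromatic carbon, gives a 1.0-fold higher number from compound 1 to compound 3 (0.01 log units; within the scatter). Going by these compounds alone, this is the first direct test of that group alone, and it shows that two quite different substituents, one carrying a double bond outside the aromatic ring and the other not, cannot be told apart at this place in this assay. The comparison of the whole rings gives a 1.6-fold higher number from compound 2 to compound 3 (0.19 log units; within the scatter), so 4-nitrophenyl, 2,6-dichlorophenyl and 4-methoxyphenyl all lie within the scatter of one another, and no available evidence accounts for this lack of separation.

Still open, going by these compounds, is whether any group on this ring can move the number beyond the scatter, such as an amine or a carboxylic acid, or whether a longer chain between the sulfur and the ring would do so. On these data alone, all three compounds also share the same core, so the effect of a change elsewhere in the molecule remains unknown.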